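Replacing methylamino with methyl on a weak compound

This account rests on a few compounds, and the source may have more. Where it says the series, first, only, none or still open, it means among the compounds named here.

Values measured in a functional assay on HeLa cells (Homo sapiens) for antiproliferative activity, read by MTT assay, with a stated time of 72 h; on this read-out higher numbers stand for weaker inhibition and lower numbers for stronger inhibition:
Compound 1 `CNc1nc(-c2cc(OC)c(OC)c(OC)c2)c(-c2ccc(C(F)(F)F)cc2)s1`: 3400 nM
Compound 2 `CNc1nc(-c2cc(OC)c(OC)c(OC)c2)c(-c2ccc(OC)cc2)s1`: 70.1 nM
Compound 3 `CCOc1ccc(-c2sc(NC)nc2-c2cc(OC)c(OC)c(OC)c2)cc1`: 13.2 nM

Of these three, compound 1 carries the highest number and so is the weakest inhibitor in this assay. Both of its steps to the others lie beyond the scatter. Methoxy in place of trifluoromethyl gives a 49-fold lower number from compound 1 to compound 2 (1.69 log units; beyond the scatter), and ethoxy in place of trifluoromethyl gives a 260-fold lower number from compound 1 to compound 3 (2.41 log units; beyond the scatter). Lengthening methoxy to ethoxy adds a more modest a 5.3-fold lower number from compound 2 to compound 3 (0.73 log units; beyond the scatter).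

Compound 4 `COc1cc(-c2nc(C)sc2-c2ccc(C(F)(F)F)cc2)cc(OC)c1OC` keeps the trifluoromethyl group of compound 1 and has methyl in place of methylamino on an aromatic carbon.

For the measured compounds named here, none of the measured steps touches the methylamino group, so the data offer no direct precedent for this change. Going by the values given here, they show only that single changes elsewhere in these compounds can move the number a long way, so a large step here cannot be ruled out. With no evidence on direction, a small rise from the weak starting point is a tentative expectation, and the range is kept wide. The expected step is a 1.5-fold higher number from compound 1 to compound 4 (0.17 log units; within the scatter). For compound 4 the estimated value is 5000 nM, with an expected range from 1200 nM to 20000 nM.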

Compound 4, half-maximal inhibitory concentration: 3830 nM
Beside the measured number, compound 4's estimate is 1.3-fold (0.12 log units) above it; measured number inside the range.
By their numbers in this assay, from the lowest: compound 3; then compound 2; then compounds 1 and 4 (each within the scatter of the next).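

In this assay, for the compounds shown here, methyl in place of methylamino on the aromatic carbon gives a 1.1-fold higher number from compound 1 to compound 4 (0.05 log units; within the scatter), the first measured step at this position, whereas the earlier steps all lay elsewhere on the core. Unlike the large steps away from the trifluoromethyl group, this change leaves compound 4 within the scatter of compound 1, even though the one nitrogen and the hydrogen-bond donor and acceptor counted for methylamino are gone, so on this weak compound the position tolerates the swap in this read-out. No measurement shown here offers an explanation for this result.

From the compounds shown here alone, the step was read only with trifluoromethyl on the other aromatic ring, so whether the same swap would stay as small on the methoxy compound 2 or the ethoxy compound 3, where the numbers are much lower, remains open. Also open, going by these compounds, is how other groups at this position would read, such as a plain amino group, dimethylamino, or a longer chain like ethylamino.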